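A few compounds are considered here, and "the series" means these few. Any claim that something is new, unique, unknown or untested is made for them only; others in the source may bear on it.

Compound 1, `COc1cc(NC(=O)Nc2cccc(F)c2)cc(OC)c1OC`: 111000 nM
Compound 2, `COc1cc(NC(=O)Nc2ccccc2)cc(OC)c1OC`: "not determined" (no result reported)
Compound 3, `COc1cc(NC(=O)Nc2ccc([N+](=O)[O-])cc2)cc(OC)c1OC`: 70800 nM

The three compounds share one core, a urea joining a trimethoxyphenyl ring to a second phenyl ring, and differ only in what that second ring carries. In a functional assay on Daoy cells (Homo sapiens) for cytotoxicity, read by MTT assay, with a stated time of 72 h (a lower number here means a stronger inhibitor, a higher number a weaker inhibitor), compound 3 gives 70800 nM, the lowest of the two numbers recorded. Compound 1 sits nearest to it, and the gap between the two lies within the usual scatter, so compound 3 cannot be called the stronger of the pair. For compound 2 no result was reported.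

Compound 4, `COc1ccc(NC(=O)Nc2cc(OC)c(OC)c(OC)c2)cc1`, has not yet been tested in this assay. It differs from compound 3 in one place: methoxy in place of nitro on an aromatic carbon. Among the measured compounds shown here, no step between two measured compounds isolates a change of this kind, so there is no measured guide for its size. Given that compound 3 and compound 1 stand within scatter of one another despite carrying different groups at that ring, the writer expects the step from compound 3 to compound 4 to be small, at most a modest move toward a higher number, a 1.4-fold higher number from compound 3 to compound 4 (0.15 log units; within the scatter). On that basis compound 4 is estimated to give 100000 nM in this assay, with a range from 40000 nM to 250000 nM.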

Compound 4, half-maximal inhibitory concentration: 14900 nM
Compound 4: the middle estimate sits 6.7-fold (0.83 log units) above what was measured; the whole stated range lies above it.
By their numbers in this assay, from the lowest: compound 4; then compounds 3 and 1 (each within the scatter of the next).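

In this assay, what the second ring carries turns out to matter: methoxy in place of nitro on an aromatic carbon, para to a large group, brings a 4.8-fold lower number from compound 3 to compound 4 (0.68 log units; beyond the scatter), the first step at this ring shown to lie beyond the scatter. Exchanging 3-fluorophenyl for 4-methoxyphenyl on an amide-type nitrogen points the same way, with a 7.4-fold lower number from compound 1 to compound 4 (0.87 log units; beyond the scatter), so compound 4 stands apart from both other compounds that have a number, while the earlier numbers alone had shown no such separation. No measurement offered here accounts for either step, and the data record only their direction and size.

The compounds shown leave open how an amine, a hydroxyl or an ethoxy group would read on the same aromatic carbon, and so whether methoxy is singular there or one of several groups that give a lower number. Nor do they tell whether the lower number goes with the arrival of methoxy or with the departure of nitro or fluoro; compound 2, which carries none of these groups, has no reported result.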